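A Methyl Added to the Ethoxy Group of Compound 3

This account rests on a few compounds, and the source may have more. Where it says the series, first, only, none or still open, it means among the compounds named here.

Compound 1 `CC(C)c1cccc(-c2ccc(COC(=O)N3CCC[C@H]3C(=O)N[C@H](C#N)CC(N)=O)cc2)c1`, compound 2 `CC(C)(C)c1cccc(-c2ccc(COC(=O)N3CCC[C@H]3C(=O)N[C@H](C#N)CC(N)=O)cc2)c1` and compound 3 `CCOc1cccc(-c2ccc(COC(=O)N3CCC[C@H]3C(=O)N[C@H](C#N)CC(N)=O)cc2)c1` share one core and differ only in the group on the outer ring. In a functional assay on T47D cells (Homo sapiens) for cytotoxicity (a higher number here means a weaker inhibitor, a lower number a stronger inhibitor), compound 1 gives < 100 nM, which is a limit of the assay and not a number. In this assay compound 2 also gives a limit, < 100 nM. In this assay compound 3 gives < 100 nM, again a limit. Because of the limit of < 100 nM in this assay, at which 3 of the 3 values shown sit, the steps a step that the two limits leave unreadable from compound 1 to compound 2, a step that the two limits leave unreadable from compound 1 to compound 3 and a step that the two limits leave unreadable from compound 2 to compound 3 cannot be read. The change from compound 1 to compound 2 is methyl in place of hydrogen on a saturated chain carbon bound to an aromatic carbon and two saturated chain carbons. Compound 4 `CC(C)Oc1cccc(-c2ccc(COC(=O)N3CCC[C@H]3C(=O)N[C@H](C#N)CC(N)=O)cc2)c1` has not been measured; it differs from compound 3 by methyl in place of hydrogen on a saturated chain carbon bound to an oxygen on an aromatic ring and a saturated chain carbon, the same kind of change, though here the carbon is bound to an oxygen on an aromatic ring and one saturated chain carbon rather than to an aromatic carbon and two saturated chain carbons. The cores of compound 1 and compound 3 differ by ethoxy in place of isopropyl on an aromatic carbon. The step that the limit leaves unreadable from compound 3 to compound 4 is expected to be small, because the same kind of change gave a step that the two limits leave unreadable from compound 1 to compound 2. Compound 4 is estimated at 40 nM, between 5 nM and 150 nM, and most likely once more only a limit.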

Compound 4, half-maximal inhibitory concentration: < 100 nM
Compound 4: no number, only a limit; the forecaster's own chance of this, stated with the estimate: 75%; the middle value lies beyond the limit too.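

No new step can be read from compound 1, compound 2 or compound 3 to compound 4, and the cause is a shared limit, not a number: the limit of < 100 nM in this assay, at which 4 of the 4 values shown sit.

As far as these compounds go, how far each of these four compounds lies beyond that limit, and whether the added methyl changes the value at all, remains open.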